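The compounds below may be only part of what the source reports. "The series", "measured", "known", "first", "only" and "open" are said of these compounds alone.

In a functional assay on MCF7 cells (Homo sapiens) for inhibition, read by MTT assay, with a stated time of 72 h (a lower number here means a stronger inhibitor, a higher number a weaker inhibitor), compound 1 `O=C1CS/C(=N\c2nc3cc(-c4ccc(Cl)cc4)[se]c3s2)N1` gives 21800 nM. Compound 2 `CN(C)c1ccc(/C=C2/S/C(=N\c3nc4cc(-c5ccc(Cl)cc5)sc4s3)NC2=O)cc1` reads > 50000 nM, which is a limit of this assay and not a number. Compound 3 `O=C1N/C(=N/c2nc3cc(-c4ccc(Cl)cc4)sc3s2)S/C1=C/c1ccc2ccccc2c1` follows from compound 2 by one change, naphthalen-2-yl in place of 4-(dimethylamino)phenyl on a double-bonded chain carbon bound to a double-bonded ring carbon. Among the compounds with values here, no measured pair shows what this change does, so only a small step towards stronger inhibition is expected, an at least 1.6-fold lower number from compound 2 to compound 3 (0.22 log units; that floor lies within the scatter). Within the data shown here, that expectation leans on compound 1 at 21800 nM, the only number so far. Compound 3 is estimated at 30000 nM, with an expected range of 12000 nM to 50000 nM.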

Compound 3, half-maximal inhibitory concentration: 15200 nM
Compound 3: middle estimate off by 2.0-fold (0.30 log units), on the high side; the measured number falls inside the stated range.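

In this assay, within the data shown here, the move to naphthalen-2-yl on a double-bonded chain carbon bound to a double-bonded ring carbon gives an at least 3.2-fold lower number from compound 2 to compound 3 (0.51 log units; beyond the scatter) and is the first readable effect of a change at this place. Compound 2 stands at a limit of the assay and not at a number, so the size of this step is only a floor: the limit of > 50000 nM in this assay, at which 1 of the 3 values shown sits.

Still open, on these data alone, is whether the loss of the dimethylamino group or the gain of the second aromatic ring carries the step. A plain phenyl or a 4-carboxyphenyl group at this place would help separate the two.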